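The compounds below may be only part of what the source reports. "The series", "measured", "known", "first", "only" and "open" are said of these compounds alone.

Compound 1 `CC(C)[C@H](NC(=O)[C@]1(Cc2ccccc2)CCN1C(=O)OCc1ccccc1)C(N)=O`. In an ADME assay on HELF cells (Homo sapiens) for cytotoxicity, with a stated time of 3 days (on this read-out lower numbers stand for higher toxicity in this test and higher numbers for lower toxicity in this test), compound 1 gives > 100000 nM, which is a limit of the assay and not a number.
Compound 2 `C[C@H](NC(=O)[C@]1(Cc2ccccc2)CCN1C(=O)OCc1ccccc1)C(=O)NC1CCCCC1`. In this assay compound 2 gives > 100000 nM, again a limit of the assay.
Compound 3 `C[C@H](NC(=O)[C@@]1(Cc2ccccc2)CCN1C(=O)OCc1ccccc1)C(=O)NC1CCCCC1`. In this assay compound 3 gives 100000 nM.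

Compound 2 thus stands at a limit in this assay, and one further value shown is likewise only a limit. The step that the two limits leave unreadable from compound 1 to compound 2 cannot be read, since both ends are limits. The step of a number no higher from compound 2 to compound 3 (the limit leaves the size open) is one whose size the limit of compound 2 leaves open; the fact that compounds 2 and 3 differ only in the configuration as drawn is all that separates that pair. Compound 4 `C[C@H](NC(=O)[C@]1(Cc2ccccc2)CCN1C(=O)OCc1ccccc1)C(=O)N(C)C` carries dimethylamino in place of cyclohexylamino on a carbonyl carbon. Among the measured compounds shown here, no measured step alters this same group, so neither step bears on it directly; the nearest, a step that the two limits leave unreadable from compound 1 to compound 2, exchanges the whole substituent on the amide-type nitrogen and is unreadable. Because the limit of > 100000 nM in this assay, at which 2 of the 3 values shown sit, marks where most of the values sit, no step beyond the scatter is expected in this assay, and a further limit is the likeliest outcome. Compound 4 is expected at 100000 nM, with a range from 40000 nM to 200000 nM. The step of a number no higher from compound 2 to compound 4 (the limit leaves the size open) is accordingly expected to be flat.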

Compound 4, minimum cytotoxic concentration: > 100000 nM
Compound 4: only a limit was reported; the forecaster's own chance of this, stated with the estimate: 80%; the middle value sits exactly at the limit.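

In this assay compound 4 gives > 100000 nM, again a limit of the assay and not a number. No new step can be read: compound 4 and both compound 1 and compound 2 stand at limits. The compounds shown leave open whether dimethylamino in place of cyclohexylamino on a carbonyl carbon changes the minimum cytotoxic concentration at all.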